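This account rests on a few compounds, and the source may have more. Where it says the series, first, only, none or still open, it means among the compounds named here.

Measured so far in an assay on HEK293 cells for agonist activity at transient receptor potential cation channel subfamily M member 8 (Homo sapiens), read by fluorescence and calcium flux, with a stated time of 15 min; on this read-out lower numbers stand for an effect already at smaller amounts and higher numbers for an effect only at larger amounts of compound:

compound 1 `CCN(Cc1cccs1)C(=O)c1cc2cc(C)ccc2o1` – 120 nM
compound 2 `Cc1ccc(OCC(=O)N(Cc2cccs2)c2c[nH]nc2C)cc1` – 0.4 nM
compound 3 `CCN(Cc1cccs1)C(=O)COc1ccc(C#N)cc1` – 1990 nM

Compound 2 stands lowest of the three numbers; compound 1 is nearest, compound 3 furthest, and both gaps lie well beyond the scatter. Among the measured compounds shown here, compounds 1 and 3 each carry an ethyl group on the amide-type nitrogen and differ from compound 2 elsewhere as well, so no single-point step is available.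

Compound 4 `Cc1ccc(OCC(=O)N(Cc2cccs2)c2ncco2)cc1` is not yet measured. Its change from compound 2: 1,3-oxazol-2-yl in place of 3-methyl-1H-pyrazol-4-yl on an amide-type nitrogen. The donor of the pyrazole is lost and an oxazole takes its place. A step upward beyond the scatter is expected, a 25-fold higher number from compound 2 to compound 4 (1.40 log units; beyond the scatter), though the size is uncertain without a matched pair. Compound 4 is expected at 10 nM, within 1 nM to 100 nM.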

Compound 4, half-maximal effective concentration: 0.3 nM
Estimate against measurement, compound 4: 33-fold (1.52 log units) above, outside the stated range (below it).
By their numbers in this assay, from the lowest: compounds 4 and 2 (each within the scatter of the next); then compound 1; then compound 3.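

In this assay, 1,3-oxazol-2-yl in place of 3-methyl-1H-pyrazol-4-yl on the amide-type nitrogen gives a 1.3-fold lower number from compound 2 to compound 4 (0.12 log units; within the scatter), so the two rings read alike at this position. The hydrogen-bond donor and the methyl group of the pyrazole are thus not required here for a number this low. Still open, on these data alone, is whether a ring is needed on this nitrogen: the compounds with ethyl there differ elsewhere too, so that step cannot be read. A phenyl ring or an aminoethyl chain at this place also remains untested in the compounds shown. Nothing at hand explains why the two rings read alike.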